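Replacing 3-nitrophenyl with 2-phenylethenyl on a shared core

A few compounds are considered here, and "the series" means these few. Any claim that something is new, unique, unknown or untested is made for them only; others in the source may bear on it.

In a functional assay on HEp-2 cells (Homo sapiens) for cytotoxicity, read by sulforhodamine B assay, with a stated time of 48 h (a higher number here means a weaker inhibitor, a lower number a stronger inhibitor), compound 1 (`CC(=O)N1N=C(c2cccc3ccccc23)CC1c1ccco1`) gives 17000 nM and compound 2 (`O=CCN1N=C(c2ccc3ccccc3c2)CC1c1cccc([N+](=O)[O-])c1`) gives 3870 nM as its half-maximal inhibitory concentration. Compound 2 therefore stands at the lower of the two numbers, and the gap between them lies beyond the scatter. Compound 3 (`O=CCN1N=C(c2ccc3ccccc3c2)CC1/C=C/c1ccccc1`) carries 2-phenylethenyl in place of 3-nitrophenyl on a saturated ring carbon. Within the data shown here, no measured pair shows this change alone, since compound 1 and compound 2 differ in more than one place. The forecast is therefore cautious: only a small move toward a higher number is expected in this assay, probably not far beyond the scatter. The estimated move is a 1.6-fold higher number from compound 2 to compound 3 (0.19 log units; within the scatter) in size. Compound 3 is expected at 6000 nM with an estimated range from 2000 nM to 18000 nM in this read-out.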

Compound 3, half-maximal inhibitory concentration: 20100 nM
The estimate for compound 3 lay 3.4-fold (0.53 log units) below the measured number; measured number outside the range, above it.
By their numbers in this assay, from the lowest: compound 2; then compounds 1 and 3 (each within the scatter of the next).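

In this assay, among these compounds, the saturated ring carbon proves sensitive to the group it bears: putting 2-phenylethenyl in place of 3-nitrophenyl gives a 5.2-fold higher number from compound 2 to compound 3 (0.72 log units; beyond the scatter), a step that no earlier pair could show alone. The change removes the nitrogen and oxygen of the leaving group and leaves an all-carbon group with one six-membered aromatic ring, so the aromatic ring itself is kept in both compounds and the higher number comes with a different group around it. Nothing measured here accounts for the size of this step.

Among the compounds shown here, the single step cannot separate the loss of the nitro group from the arrival of the ethenyl link. On these data alone, an unsubstituted phenyl, or a 3-aminophenyl, on the same carbon could show which of the two carries the difference, and whether the number at this position can fall further remains open.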